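A few compounds are considered here, and "the series" means these few. Any claim that something is new, unique, unknown or untested is made for them only; others in the source may bear on it.

Compound 1 `Cc1cccc(NC(=O)CCN2CCN(c3ncccn3)CC2)c1`: 2120 nM
Compound 2 `O=C(CN1CCN(c2ccccn2)CC1)Nc1cncnc1`: > 100000 nM

Among the measured compounds shown here, in a functional assay on cells for antagonist activity at D(4) dopamine receptor (Homo sapiens), read by TR-FRET and cAMP accumulation, with a stated time of 30 min (a lower number here means a stronger inhibitor, a higher number a weaker inhibitor), compound 1 gives 2120 nM, the only number in this set. Compound 2 sits at the limit of > 100000 nM in this assay, at which 1 of the 2 values shown sits, a limit of the assay rather than a number. Compound 3 `Cc1cccc(NC(=O)CCN2CCN(c3ccccn3)CC2)c1` has not yet been measured in this assay. It differs from compound 1 by pyridin-2-yl in place of pyrimidin-2-yl on an amine nitrogen in a ring. For the measured compounds named here, no measured step between any two compounds is available to set the size of such a change. The expected step for compound 3 is a 1.4-fold lower number from compound 1 to compound 3 (0.15 log units; within the scatter), a small shift toward stronger inhibition that may well lie within the scatter. Compound 3 is thus estimated at 1500 nM, with a range of 400 nM to 6000 nM.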

Compound 3, half-maximal inhibitory concentration: 1630 nM
Compound 3: middle estimate off by 1.1-fold (0.04 log units), on the low side; measured number inside the range.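

In this assay, pyridin-2-yl in place of pyrimidin-2-yl on the amine nitrogen in the ring gives a 1.3-fold lower number from compound 1 to compound 3 (0.11 log units; within the scatter). This first measured step at this position shows that the group can lose one ring nitrogen and one hydrogen-bond acceptor with no change beyond the scatter. Nothing measured here gives a reason for this step.

From the compounds shown here alone, what remains open is whether this tolerance extends to a phenyl ring, which has no ring nitrogen, or to a small alkyl group such as methyl on that nitrogen.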